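Series notes: thiophen-2-yl in place of quinolin-5-yl

The source may hold more compounds than are shown below. What is called first, only, known or untested is meant among the compounds shown, and "the series" means these compounds.

Measured in a functional assay on MDA-MB-231 cells (Homo sapiens) for antiproliferative activity, read by MTT assay, with a stated time of 48 h; a lower number here means a stronger inhibitor, a higher number a weaker inhibitor:
- compound 1 `C=CS(=O)(=O)N1CCN(c2ncnc3sc(-c4cccc5ncccc45)cc23)CC1`: 21000 nM
- compound 2 `C=CS(=O)(=O)N1CCN(c2ncnc3sc(-c4cnn(Cc5ccccc5)c4)cc23)CC1`: 19100 nM

In this assay compound 1 gives 21000 nM, and compound 2 gives 19100 nM. These two values lie within the scatter of each other, so neither compound can be ranked above the other. Within the data shown here, no measured step isolates a single structural change.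

The next compound is compound 3 `C=CS(=O)(=O)N1CCN(c2ncnc3sc(-c4cccs4)cc23)CC1`, with thiophen-2-yl in place of quinolin-5-yl on an aromatic carbon. Among the measured compounds shown here, the only guide is that compound 1 at 21000 nM and compound 2 at 19100 nM differ at this place yet show no separation. A change beyond the scatter in this assay is therefore not expected, in either direction. The expected change is a 1.2-fold lower number from compound 1 to compound 3 (0.07 log units; within the scatter). For compound 3 the estimate is 18000 nM, with an expected range of 7000 nM to 45000 nM.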

Compound 3, half-maximal inhibitory concentration: 34100 nM
Compound 3: the middle estimate sits 1.9-fold (0.28 log units) below what was measured, and the stated range covers the measured number.
By their numbers in this assay, from the lowest: compounds 2, 1 and 3 (each within the scatter of the next).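

In this assay, among these compounds, thiophen-2-yl in place of quinolin-5-yl on an aromatic carbon gives a 1.6-fold higher number from compound 1 to compound 3 (0.21 log units; within the scatter) and is the first single-place step read at this position. The substituent goes from 10 heavy atoms to 5, and from two fused six-membered aromatic rings to one five-membered aromatic ring, yet the two compounds remain unseparated in this assay. No measured evidence bears on this result.

On these data alone, all three compounds carry an aromatic ring at this place, so it remains open whether a different kind of group, such as a morpholine, a primary amine or a carboxylic acid, would move the number beyond the scatter. The same question applies to a substituent on the thiophene ring of compound 3, such as a methyl group or a chlorine atom.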